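The source may report more compounds than this note shows. Statements on the series, on what has been measured and on what is new or still open speak of the compounds shown alone.

Compound 1, `COc1ccc(Nc2cncc(N3CC4CC(C3)N4)c2)cc1`, gives 0.0598 nM.
Compound 2, `Clc1cccc(Nc2ccc(N3CC4CC(C3)N4)nn2)c1`, gives 1540 nM.
Compound 3, `Clc1ccc(Nc2cncc(N3CC4CC(C3)N4)c2)cc1`, gives 0.118 nM.

All three were measured in an assay on cell membranes for displacement of a labelled ligand from Neuronal acetylcholine receptor; alpha4/beta2 (Rattus norvegicus); a lower number here means a stronger inhibitor, a higher number a weaker inhibitor. Compound 2 stands highest of the three numbers, far from both compound 1 and compound 3, and is the weakest binder in this set; its core differs from the shared core of compound 1 and compound 3. Within the data shown here, the only step measured between two compounds that differ in one place is a 2.0-fold higher number from compound 1 to compound 3 (0.30 log units; within the scatter), an exchange of one substituent on the aryl ring that left the number essentially unchanged.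

Compound 4, `Fc1ccc(Nc2ccc(N3CC4CC(C3)N4)nn2)cc1`, has not been measured. It differs from compound 2 by 4-fluorophenyl in place of 3-chlorophenyl on a nitrogen on an aromatic ring. The measured step bears on this only loosely: it concerns a different core and a different pair of substituents, and it says that a swap on the aryl ring need not move the number. Nothing measured shows what a halogen at a different position on the phenyl, or fluoro in place of chloro, does on the core of compound 2. The expectation is therefore no step beyond the scatter, stated with wide uncertainty: compound 4 is estimated at 1200 nM in this assay, with a range from 200 nM to 7000 nM, which means an expected step of a 1.3-fold lower number from compound 2 to compound 4 (0.11 log units; within the scatter).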

Compound 4, inhibition constant: 868 nM
For compound 4 the middle estimate is 1.4-fold (0.14 log units) above the measured one; the range from low to high includes it.
By their numbers in this assay, from the lowest: compounds 1 and 3 (each within the scatter of the next); then compounds 4 and 2 (each within the scatter of the next).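

Among these compounds, on the core of compound 2, this assay now gives a first measured step for an exchange of the aryl group: 4-fluorophenyl in place of 3-chlorophenyl on a nitrogen on an aromatic ring gives a 1.8-fold lower number from compound 2 to compound 4 (0.25 log units; within the scatter). Among the compounds shown here, earlier, the only such information came from the shared core of compound 1 and compound 3, so this result shows that on a second core, too, this kind of exchange need not move the number beyond the usual scatter. Nothing measured here accounts for that result.

The halogen and its place on the phenyl ring changed together, so the compounds shown cannot separate what each change does alone, and a result within the scatter does not prove that either change is without effect. Also open, going by these compounds, is whether a different kind of group on the core of compound 2, such as a phenyl ring carrying an amine or a carboxylic acid, or a longer chain in place of the phenyl ring, would shift the number well beyond the scatter.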